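This account rests on a few compounds, and the source may have more. Where it says the series, first, only, none or still open, it means among the compounds named here.

Measured so far:
Compound 1 `O=C(O)Cc1sc(C(c2ccc(F)cc2)c2ccc(F)cc2)nc1-c1cc(F)cc(F)c1`: 35 nM
Compound 2 `O=C(O)Cc1sc(C(c2ccccc2)c2ccc(O)cc2)nc1-c1ccc(F)cc1`: 3.4 nM
Compound 3 `COc1ccc(C(c2ccccn2)c2nc(-c3ccc(Cl)cc3)c(CC(=O)O)s2)cc1`: 61 nM

All three were tested in an in vitro assay on HEK385-7 cells for displacement of a labelled ligand from prostaglandin D2 receptor 2 (Homo sapiens); a lower number here means a stronger inhibitor, a higher number a weaker inhibitor. Among these numbers compound 1 stands second highest. Compound 3 lies within the usual scatter of compound 1, so the two cannot be told apart, whereas compound 2 gives a clearly lower number, beyond the scatter, and so is the stronger inhibitor of that pair.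

Compound 4 `Nc1cc(-c2nc(C(c3ccc(F)cc3)c3ccc(F)cc3)sc2CC(=O)O)cc(F)n1` has not yet been measured in this assay. It differs from compound 1 in one place: 2-amino-6-fluoropyridin-4-yl in place of 3,5-difluorophenyl on an aromatic carbon. For the measured compounds named here, no pair of measured compounds shows this particular change, so its effect cannot be read from the data; a modest step, leaning toward a lower number but not far beyond the scatter, seems most plausible. Compound 4 is therefore expected to give about 25 nM, with a likely range from 8 nM to 80 nM. The expected step is a 1.4-fold lower number from compound 1 to compound 4 (0.15 log units; within the scatter).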

Compound 4, half-maximal inhibitory concentration: 220 nM
The estimate for compound 4 lay 8.8-fold (0.94 log units) below the measured number, and the stated range ends below it.
By their numbers in this assay, from the lowest: compound 2; then compounds 1 and 3 (each within the scatter of the next); then compound 4.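

In this assay the group on the aromatic carbon next to the ring nitrogen cannot be swapped freely: 2-amino-6-fluoropyridin-4-yl in place of 3,5-difluorophenyl gives a 6.3-fold higher number from compound 1 to compound 4 (0.80 log units; beyond the scatter) and this step lies beyond the scatter. Both groups count the same number of heavy atoms, so that count alone does not predict the outcome here. Nothing available explains this step.

For the compounds shown here, the single change brings in both an amine and a ring nitrogen, and their separate shares remain open. Also open, from the compounds shown here alone, is how a nitrile on the 3,5-difluorophenyl ring would compare.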